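Pyridyl isomers on the pyrrole nitrogen: kinetic solubility

The source may hold more compounds than are shown below. What is called first, only, known or untested is meant among the compounds shown, and "the series" means these compounds.

Measured so far:
compound 1 `CCOC(=O)C1=C(C)N/C(=C/c2cc(C)n(-c3ccc(F)cc3F)c2C)C1=O` — 3.1 ug/mL
compound 2 `CCOC(=O)C1=C(C)N/C(=C/c2cc(C)n(-c3ccncc3)c2C)C1=O` — 100 ug/mL

In a physicochemical assay for solubility, read by nephelometry, measured as kinetic solubility, at pH 2.0 (on this read-out lower numbers stand for lower solubility and higher numbers for higher solubility), compound 2 gives 100 ug/mL, the highest of the two numbers measured; the nearest is compound 1 with 3.1 ug/mL. Within the data shown here, the one measured step, a 32-fold higher number from compound 1 to compound 2 (1.51 log units; beyond the scatter), exchanges the whole aromatic group on the pyrrole nitrogen. Compound 3 `CCOC(=O)C1=C(C)N/C(=C/c2cc(C)n(-c3cccnc3)c2C)C1=O` differs from compound 2 by pyridin-3-yl in place of pyridin-4-yl on an aromatic nitrogen. Among the measured compounds shown here, no measured step exchanges one pyridyl for another, so that step gives no direct guidance. Compound 3 is therefore expected to show no change at the digits printed from compound 2 to compound 3 (within the scatter), with an estimated value of 100 ug/mL in the range 40 ug/mL to 250 ug/mL.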

Compound 3, solubility: > 50 ug/mL
Compound 3: no number, only a limit; the forecaster's own chance of this, stated with the estimate: 15%; the middle value is on the limit's open side.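

In this assay compound 3 gives > 50 ug/mL, which is a limit and not a number. Pyridin-3-yl in place of 2,4-difluorophenyl still gives an at least 16-fold higher number from compound 1 to compound 3 (1.20 log units; beyond the scatter), so a large step at this position is not confined to pyridin-4-yl. The step from compound 2 to compound 3 cannot be read, which leaves the two pyridyl isomers unordered: the limit of > 50 ug/mL in this assay, at which 1 of the 3 values shown sits.

As far as these compounds go, whether pyridin-2-yl would give a similar step on this aromatic nitrogen remains open. So does the outcome for a pyrimidinyl ring or an aminophenyl group there.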